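Swapping the azidoethyl group on a long-chain compound

The source may hold more compounds than are shown below. What is called first, only, known or untested is meant among the compounds shown, and "the series" means these compounds.

Measured in a functional assay on HCT-116 cells (Homo sapiens) for antiproliferative activity, read by MTT assay, with a stated time of 48 h; on this read-out lower numbers stand for stronger inhibition and higher numbers for weaker inhibition:
- compound 1 `C=C(CO)C(CCCCC)n1cnc2c(Cl)ncnc21`: > 50000 nM (a limit of the assay, not a number)
- compound 2 `C=C(CO)C(CCCCCCC)n1cnc2c(Cl)ncnc21`: 22400 nM
- compound 3 `CCCCCCCCCC(CCN=[N+]=[N-])n1cnc2c(Cl)ncnc21`: 1040 nM

Compound 3 has the lowest number of the three, so it inhibits most strongly here. The next structure is compound 4 `C=C(CO)C(CCCCCCCCC)n1cnc2c(Cl)ncnc21`, and the change is 1-(hydroxymethyl)ethenyl in place of 2-azidoethyl on a saturated chain carbon bound to an aromatic nitrogen and a saturated chain carbon. Going by the values given here, the entering group is the one carried by compounds 1 and 2. Among the compounds with values here, the only measured step is an at least 2.2-fold lower number from compound 1 to compound 2 (0.34 log units; beyond the scatter), a chain lengthening that lowered the number. Compound 4 keeps the longer chain of compound 3, so a number under that of compound 2 at 22400 nM is expected, though still above that of compound 3 at 1040 nM. The expected change is a 6.7-fold higher number from compound 3 to compound 4 (0.83 log units; beyond the scatter), a clear weakening. For compound 4 the estimated value in this assay is 7000 nM, with an expected range of 2500 nM to 20000 nM.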

Compound 4, half-maximal inhibitory concentration: > 50000 nM
Compound 4: no number, only a limit; the forecaster's own chance of this, stated with the estimate: 8%; middle value at least 7.1-fold (0.85 log units) from the limit.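

On the saturated chain carbon bound to an aromatic nitrogen and a saturated chain carbon, 1-(hydroxymethyl)ethenyl in place of 2-azidoethyl costs much of the activity in this assay, with an at least 48-fold higher number from compound 3 to compound 4 (1.68 log units; beyond the scatter). Lengthening the chain also no longer helps, with an at least 2.2-fold higher number from compound 2 to compound 4 (0.34 log units; beyond the scatter), so the earlier gain from compound 1 to compound 2 does not continue. The step from compound 1 to compound 4 cannot be read because both values are limits: the limit of > 50000 nM in this assay, at which 2 of the 4 values shown sit.

From the compounds shown here alone, it remains open whether 2-aminoethyl could stand in for 2-azidoethyl on compound 3. Going by these compounds, the effect of a longer chain on compound 3 also remains open.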